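The source may hold more compounds than are shown below. What is called first, only, known or untested is meant among the compounds shown, and "the series" means these compounds.

Three compounds share one core and differ only in the group on the carbonyl carbon. Compound 1 `Cc1cccc(Cn2c(CN3CCN(C(=O)C4CCCC4)CC3)nc3ccccc32)c1` gives 67.5% in an assay on isolated protein for inhibition of aldehyde dehydrogenase 1A1 (Homo sapiens), read by spectrophotometry, tested at 10 uM; a lower number here means less inhibition, a higher number more inhibition at the concentration tested (going by the name of the read-out). Compound 2 `CCc1ccc(C(=O)N2CCN(Cc3nc4ccccc4n3Cc3cccc(C)c3)CC2)cc1` gives 67% in this assay, and compound 3 `Cc1cccc(Cn2c(CN3CCN(C(=O)c4cccs4)CC3)nc3ccccc32)c1` gives 60.8% in this assay. Compound 3 holds the lowest of the three numbers, yet the steps to it, a number 6.7 percentage points lower from compound 1 to compound 3 (within the scatter) and a number 6.2 percentage points lower from compound 2 to compound 3 (within the scatter), both sit within the scatter, as does a number 0.5 percentage points lower from compound 1 to compound 2 (within the scatter), so no ordering among the three is supported. Compound 4 `Cc1cccc(Cn2c(CN3CCN(C(=O)c4ccco4)CC3)nc3ccccc32)c1` carries furan-2-yl in place of thiophen-2-yl on a carbonyl carbon. All three measured steps exchange the group on the carbonyl carbon without moving the read-out beyond the scatter, so in this assay a step of a number 0.2 percentage points higher from compound 3 to compound 4 (within the scatter) is expected, none beyond the scatter. Compound 4 is accordingly estimated at 61%, with a range of 50% to 72%.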

Compound 4, a percentage reported as inhibition, at one concentration (the size of the read-out at that concentration, not a potency): 73.2%
Estimate against measurement, compound 4: 12.2 percentage points below; measured number outside the range, above it.
By their numbers in this assay, from the lowest: compounds 3, 2, 1 and 4 (each within the scatter of the next, the first and the last beyond it).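

In this assay the carbonyl position gives its first step beyond the scatter, a number 12.4 percentage points higher from compound 3 to compound 4 (beyond the scatter) when furan-2-yl replaces thiophen-2-yl. The two groups have the same counts and differ by one ring atom, oxygen for sulfur, so even this small exchange registers here, although a number 6.2 percentage points higher from compound 2 to compound 4 (within the scatter) and a number 5.7 percentage points higher from compound 1 to compound 4 (within the scatter) leave compound 4 unseparated from the 4-ethylphenyl and cyclopentyl amides. Nothing available bears on the reason for the step.

On these data alone, whether a pyridin-2-yl or a morpholine on the carbonyl carbon would move beyond the scatter from compound 4 remains open. So does whether the thiophen-2-yl to furan-2-yl step holds on another core.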